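Cytotoxicity of Three Measured Compounds and One Expected

The source may hold more compounds than are shown below. What is called first, only, known or untested is meant among the compounds shown, and "the series" means these compounds.

Compound 1 `COc1ccc(NC(=O)CCc2cccc3c2B(O)OC3)cc1` gives > 100000 nM in an ADME assay on WI-38 cells (Homo sapiens) for cytotoxicity, read by MTT assay, with a stated time of 72 h (a lower number here means a stronger inhibitor, a higher number a weaker inhibitor), a limit of the assay and not a number. Compound 2 `COc1ccc(NC(=O)CCc2cccc3c2B(O)OC3)cc1OC` gives > 100000 nM in this assay, again a limit. Compound 3 `COc1cccc(-c2cccc(NC(=O)CCc3ccc4c(c3)COB4O)c2)c1` gives > 100000 nM in this assay, also a limit.

The step from compound 1 to compound 2 is methoxy in place of hydrogen on an aromatic carbon. In this assay its size is a step that the two limits leave unreadable from compound 1 to compound 2, and the reason it cannot be read is the limit of > 100000 nM in this assay, at which 3 of the 3 values shown sit. The difference between the core of compound 1 and the core of compound 3 is not broken down here.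

Compound 4 `COc1cc(OC)cc(-c2cccc(NC(=O)CCc3ccc4c(c3)COB4O)c2)c1` has not been measured in this assay. It differs from compound 3 by methoxy in place of hydrogen on an aromatic carbon. Within the data shown here, this is the same kind of change as the one from compound 1 to compound 2, but not the same: in compound 2 the entering methoxy sits ortho to a methoxy group and meta to a large group, while in compound 4 it sits meta to a large group and meta to a methoxy group.

For compound 4 the step in this assay is expected to be a step that the limit leaves unreadable from compound 3 to compound 4, resting on compound 3 at > 100000 nM and on the pair compound 1 and compound 2, both of which sit at the limit. Compound 4 is therefore expected to fall at 200000 nM, most likely reported only as a limit again, with a range from 60000 nM to 1000000 nM.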

Compound 4, half-maximal inhibitory concentration: > 100000 nM
Compound 4 ended at the assay's limit; the forecaster's own chance of this, stated with the estimate: 85%; the middle value is on the limit's open side.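

No size can be read for the step from compound 3 to compound 4 in this assay, because both compounds end at a limit of the assay and not at a number: the limit of > 100000 nM in this assay, at which 4 of the 4 values shown sit.

The compounds shown leave open whether methoxy in place of hydrogen on an aromatic carbon has any effect in this assay, and they give no order among compound 1, compound 2, compound 3 and compound 4.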